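The source may report more compounds than this note shows. Statements on the series, on what has been measured and on what is new or still open speak of the compounds shown alone.

Measured so far:
compound 1 `COc1cccc(F)c1-c1cccc2nc(N)oc12`, only a limit in an assay on BAF cells for inhibition of ribosomal protein S6 kinase alpha-2 (Mus musculus); a lower number here means a stronger inhibitor, a higher number a weaker inhibitor: > 20000 nM
compound 2 `COc1ccc(Nc2nc3cccc(-c4c(F)cccc4OC)c3o2)cc1`, again only a limit in this assay: > 20000 nM
compound 3 `COc1ccccc1-c1cccc2nc(Nc3cc(OC)c(OC)c(OC)c3)oc12`, a measured number in this assay: 5700 nM

Among the compounds with values here, compound 3 is thus the only compound of the three with a number; the other two sit at the limit of > 20000 nM in this assay, at which 2 of the 3 values shown sit. Within the data shown here, the one measured step, a step that the two limits leave unreadable from compound 1 to compound 2, runs between two limits and cannot be read, and it alters the nitrogen substituent, not the aryl ring.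

Compound 4 `COc1ccc(F)cc1-c1cccc2nc(Nc3cc(OC)c(OC)c(OC)c3)oc12` differs from compound 3 by fluoro in place of hydrogen on an aromatic carbon. Among the measured compounds shown here, no measured step concerns this change, so the step in this assay is expected to stay within the scatter, a 1.1-fold lower number from compound 3 to compound 4 (0.06 log units; within the scatter). Compound 4 is therefore estimated at 5000 nM, within 1500 nM to 16000 nM.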

Compound 4, half-maximal inhibitory concentration: 3700 nM
The estimate for compound 4 lay 1.4-fold (0.13 log units) above the measured number; the range from low to high includes it.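

On the 2-methoxyphenyl ring, fluoro on the aromatic carbon para to the methoxy group gives in this assay a 1.5-fold lower number from compound 3 to compound 4 (0.19 log units; within the scatter), so 5-fluoro-2-methoxyphenyl is accepted here without a change beyond the scatter. Within the data shown here, this is the first readable step, and it concerns the aryl ring; the only earlier step runs between two limits and cannot be read. No data shown bear on the size of this step.

On these data alone, whether an amine, a carboxylic acid or a longer chain at this carbon would move the number beyond the scatter stays open. Among these compounds, also open is whether fluoro behaves the same way with a nitrogen substituent other than the one shared by compound 3 and compound 4.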